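The source may hold more compounds than are shown below. What is called first, only, known or untested is meant among the compounds shown, and "the series" means these compounds.

Measured compounds:
- Compound 1 `COC(=O)/C=C/C(=O)N[C@@H](C)Cn1ccc(-c2ccc(C#N)c(Cl)c2)n1` — in an ADME assay on PC-3 cells (Homo sapiens) for cytotoxicity, read by CCK-8 assay, with a stated time of 6 days (on this read-out higher numbers stand for weaker inhibition and lower numbers for stronger inhibition), compound 1 gives > 30000 nM, a limit of the assay rather than a number.
- Compound 2 `C[C@@H](Cn1ccc(-c2ccc(C#N)c(Cl)c2)n1)Nc1ccccc1` — in this assay compound 2 gives 3210 nM.

Among the compounds with values here, compound 2 holds the only numerical value; the other entry is a limit. Within the data shown here, the step of an at least 9.3-fold lower number from compound 1 to compound 2 (0.97 log units; beyond the scatter) is the one measured change, and it bears on compound 3 only loosely, since it swaps an acyl group for an aryl group rather than one aryl for another.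

Compound 3 `C[C@@H](Cn1ccc(-c2ccc(C#N)c(Cl)c2)n1)Nc1cccnc1` differs from compound 2 by pyridin-3-yl in place of phenyl on an amine nitrogen. Among the measured compounds shown here, no measured step tests an aryl-for-aryl exchange, so the expectation rests on the size of compound 2's value alone. Compound 3 is expected to land close to compound 2, with a step of a 1.2-fold higher number from compound 2 to compound 3 (0.10 log units; within the scatter) that is not expected to exceed the usual scatter. The estimate for compound 3 in this assay is 4000 nM, with a range from 1500 nM to 12000 nM.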

Compound 3, half-maximal inhibitory concentration: > 30000 nM
Compound 3 gave a limit, no number (the forecaster's own chance of this, stated with the estimate: 10%); middle value at least 7.5-fold (0.87 log units) from the limit.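

In this assay, pyridin-3-yl in place of phenyl on an amine nitrogen gives an at least 9.3-fold higher number from compound 2 to compound 3 (0.97 log units; beyond the scatter), so this position responds to an exchange of one six-membered aromatic ring for another, and not only to the acyl-for-aryl exchange seen earlier. Compound 3 shares a limit with compound 1, which leaves compound 2, with its phenyl group, as the only compound shown that gives a number: the limit of > 30000 nM in this assay, at which 2 of the 3 values shown sit. The step from compound 1 to compound 3 cannot be read: both values are limits.

Going by these compounds, it remains open whether pyridin-2-yl, pyridin-4-yl, fluorophenyl or methoxyphenyl on the same amine nitrogen would read close to compound 2 or reach the limit. On these data alone, the true size of the step to compound 3 also stays unknown, since only a limit is available.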